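The source may report more compounds than this note shows. Statements on the series, on what has been measured and on what is new or still open speak of the compounds shown alone.

Compounds measured so far:
compound 1, `CC1=C(C(=O)OC(C)C)[C@@H](c2ccco2)N/C(=N/C#N)N1` — in an assay on HeLa cells for displacement of a labelled ligand from adenosine receptor A3 (Homo sapiens), with a stated time of 180 min, tested at 1 uM (on this read-out higher numbers stand for more inhibition at the one concentration tested (going by the name of the read-out) and lower numbers for less inhibition), compound 1 gives 4%
compound 2, `CC1=C(C(=O)OC(C)C)C(c2ccccc2)N/C(=N/C#N)N1` — in this assay compound 2 gives 6%
compound 3, `CC1=C(C(=O)OC(C)C)C(c2ccco2)N/C(=N/C#N)N1` — in this assay compound 3 gives 4%

Compound 3 stands level with compound 1 at the digits printed, the two together being the lowest of the three numbers; compound 2 sits only slightly apart, with a number 2 percentage points lower from compound 2 to compound 3 (within the scatter). The next compound, compound 4 `CC1=C(C(=O)OC(C)C)[C@H](c2ccco2)N/C(=N/C#N)N1`, differs from compound 3 by the two compounds have the same atoms and bonds; at least one stereo element is drawn with a configuration in one of them and without one in the other: 1 of 2 stereo elements differ; a stereocentre at a saturated ring carbon is drawn without a configuration in compound 3 and R in compound 4. Going by the values given here, the one step that bears on this is the drawing of the same stereocentre in compound 1, where no change at the digits printed from compound 1 to compound 3 (within the scatter), a finding to be read in the light of the fact that one of compounds 1 and 3 is drawn with a defined configuration and the other without, at the place where they differ. Nothing in these numbers points to a shift beyond the scatter, so the step is expected to be no change at the digits printed from compound 3 to compound 4 (within the scatter). Compound 4 is therefore estimated at 4%, within a range of 0% to 12%.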

Compound 4, a percentage reported as inhibition, at one concentration (the size of the read-out at that concentration, not a potency): 1%
Compound 4: middle estimate off by 3 percentage points, on the high side; the measured number falls inside the stated range.
By their numbers in this assay, from the lowest: compounds 4, 1, 3 and 2 (each within the scatter of the next).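

In this assay, going by these compounds alone, the R drawing gives a number 3 percentage points lower from compound 3 to compound 4 (within the scatter), and the first direct comparison of the two defined configurations gives a number 3 percentage points lower from compound 1 to compound 4 (within the scatter). With furan-2-yl on the saturated ring carbon, the configuration drawn at that stereocentre therefore does not separate the compounds at the one concentration tested. The compounds shown leave open whether a longer chain or an amine on that carbon would move the number beyond the scatter, and whether configuration would then separate the two forms.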